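Swapping the aryl group between compound 2 and compound 3

The compounds below may be only part of what the source reports. "The series", "measured", "known", "first", "only" and "open" are said of these compounds alone.

compound 1 `Clc1cccc(-c2cc(-c3ccc(Cl)o3)cc(-c3cccs3)n2)c1` — 42%
compound 2 `Cc1ccc(-c2cc(-c3ccc(Cl)o3)cc(-c3ccsc3)n2)cc1` — 2.6%

In an assay on isolated protein for inhibition of DNA topoisomerase 1 (Homo sapiens), tested at 100 uM (a lower number here means a weaker effect, a higher number a stronger effect of the compound at the concentration tested), compound 1 gives 42% and compound 2 gives 2.6%. Compound 2 stands lowest of the two, with compound 1 its nearest neighbour at a distance beyond the scatter. Compound 3 `Clc1cccc(-c2cc(-c3ccc(Cl)o3)cc(-c3ccsc3)n2)c1` differs from compound 2 in one place: 3-chlorophenyl in place of 4-methylphenyl on an aromatic carbon. For the measured compounds named here, no measured pair shows this change alone, and compound 1 differs from compound 3 elsewhere as well, so the step cannot be read directly. Still, compound 1 carries the same 3-chlorophenyl group and gives 42%. An upward step beyond the scatter is therefore expected, a number 19.4 percentage points higher from compound 2 to compound 3 (beyond the scatter). Compound 3 is estimated at 22%, between 4% and 45%.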

Compound 3, a percentage reported as inhibition, at one concentration (the size of the read-out at that concentration, not a potency): 0%
Beside the measured number, compound 3's estimate is 22 percentage points above it, outside the stated range (below it).
By their numbers in this assay, from the lowest: compounds 3 and 2 (each within the scatter of the next); then compound 1.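

In this assay, 3-chlorophenyl in place of 4-methylphenyl next to the ring nitrogen gives a number 2.6 percentage points lower from compound 2 to compound 3 (within the scatter), so with thiophen-3-yl present this aryl swap shows no measurable response. With 3-chlorophenyl held fixed, thiophen-3-yl in place of thiophen-2-yl gives a number 42 percentage points lower from compound 1 to compound 3 (beyond the scatter), which places the large difference at the thiophene attachment rather than at the aryl group. No evidence given here explains either step. As far as these compounds go, it remains open whether 4-methylphenyl would keep the level of compound 1 alongside thiophen-2-yl. From the compounds shown here alone, how an amine or a carboxylic acid on this phenyl ring would read also remains open.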